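Chloro-to-fluoro swaps across the shared core

The compounds below may be only part of what the source reports. "The series", "measured", "known", "first", "only" and "open" are said of these compounds alone.

Three measured compounds share one core. Compound 1 `Cc1cc(Nc2cc(-c3ccccc3)[nH]n2)n2nc(SCc3ccc(F)cc3)nc2n1` gives 3270 nM in a functional assay on MGC-803 cells (Homo sapiens) for inhibition, read by MTT assay, with a stated time of 72 h; a higher number here means a weaker inhibitor, a lower number a stronger inhibitor. Compound 2 `Cc1cc(Nc2cc(-c3ccccc3)[nH]n2)n2nc(SCc3ccc(Cl)cc3)nc2n1` gives 3950 nM in this assay. Compound 3 `Cc1cc(Nc2cc(-c3ccc(Cl)cc3)[nH]n2)n2nc(SCc3ccc(Br)cc3)nc2n1` gives 2780 nM in this assay; it stands at the lowest of the three numbers, but its gaps to compound 1 and compound 2 are within the scatter, so no order among the three is claimed.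

One single-point change is seen twice. Between compound 2 and compound 1 it reads fluoro in place of chloro on an aromatic carbon and made a 1.2-fold lower number from compound 2 to compound 1 (0.08 log units; within the scatter). How the core of compound 3 differs from that of compound 2 is not broken down here.

Compound 4 `Cc1cc(Nc2cc(-c3ccc(F)cc3)[nH]n2)n2nc(SCc3ccc(Br)cc3)nc2n1` is not yet measured. It differs from compound 3 by fluoro in place of chloro on an aromatic carbon, the same kind of change as from compound 2 to compound 1, though cut one bond further out it reads 4-chlorophenyl to 4-fluorophenyl on the other ring rather than on the (4-chlorobenzyl)sulfanyl group.

Because the earlier swap gave a 1.2-fold lower number from compound 2 to compound 1 (0.08 log units; within the scatter), a step within the scatter, the expectation for compound 4 is a number close to that of compound 3, estimated as a 1.0-fold higher number from compound 3 to compound 4 (0.02 log units; within the scatter). Compound 4 is thus expected to give about 2900 nM in this assay, with a range estimated from 1500 nM to 6000 nM. This rests on a single precedent and on compound 3 alone.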

Compound 4, half-maximal inhibitory concentration: 2210 nM
Compound 4: the middle estimate sits 1.3-fold (0.12 log units) above what was measured, within the range that was stated.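

In this assay, the change from 4-chlorophenyl to 4-fluorophenyl gave a 1.3-fold lower number from compound 3 to compound 4 (0.10 log units; within the scatter), so on this ring the swap of chloro for fluoro leaves no readable change. Set beside the earlier swap on the benzyl group of the sulfanyl side, the step carries over from one core to the other without a visible difference: the same change on two cores in this assay, a 1.2-fold lower number (0.08 log units; within the scatter) from compound 2 to compound 1 and a 1.3-fold lower number (0.10 log units; within the scatter) from compound 3 to compound 4, 1.0-fold (0.02 log units) apart, within the scatter of two such steps. For the compounds shown here, this shows only that the swap stayed within the scatter in both pairs, and it gives no real direction or size for the change: two steps this small do not establish a trend, and they say nothing about other cores or about the same swap at any other place on these molecules.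

The compounds shown carry only halogens on the benzyl group and on the phenyl ring, if anything at all, so it remains open whether an amine, a carboxylic acid or a methoxy group at these places would move the number in this assay beyond the scatter. Also open, from the compounds shown here alone, is whether a longer chain in place of the benzyl group on the sulfur would do so, and whether any substituent at all on this series can separate these compounds in this assay.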